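The source may hold more compounds than are shown below. What is called first, only, known or untested is meant among the compounds shown, and "the series" means these compounds.

Of the compounds shown here, three built on one shared core have been measured in a functional assay on HEK293 cells for positive allosteric modulation of metabotropic glutamate receptor 5 (Rattus norvegicus), read by fluorescence and calcium flux; on this read-out higher numbers stand for larger maximal responses and lower numbers for smaller maximal responses. Compound 1 `C[C@H](NC(=O)c1ccc(C#Cc2cccc(F)c2)cn1)C(C)(C)C` reaches 70.8%, compound 2 `CC(C)[C@@H](C)NC(=O)c1ccc(C#Cc2cccc(F)c2)cn1` reaches 69.3%, and compound 3 `CC(C)(O)CCNC(=O)c1ccc(C#Cc2cccc(F)c2)cn1` reaches 61.9%. Compound 3 holds the lowest of the three numbers, yet its neighbours sit close by: the step of a number 8.9 percentage points lower from compound 1 to compound 3 (within the scatter) and the step of a number 7.4 percentage points lower from compound 2 to compound 3 (within the scatter) both fall within the scatter, as does a number 1.5 percentage points lower from compound 1 to compound 2 (within the scatter). So far, exchanging the group on the amide-type nitrogen has not moved the maximal response beyond the usual spread.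

Compound 4 `CC1(CNC(=O)c2ccc(C#Cc3cccc(F)c3)cn2)COC1` has not yet been measured. It differs from compound 3 by 3-methyloxetan-3-yl in place of 2-hydroxy-2-methylpropyl on a saturated chain carbon bound to an amide-type nitrogen. The 2-hydroxy-2-methylpropyl that leaves carries one hydrogen-bond donor; the 3-methyloxetan-3-yl that enters carries none and brings a four-membered non-aromatic ring with one hetero atom, at the saturated chain carbon bound to the amide-type nitrogen.

Within the data shown here, none of the measured steps swaps an open chain with a hydroxyl for such a ring, so they bear on this change only loosely. Still, all three stayed within the scatter, which gives no reason to expect a larger movement here. The step of a number 2.1 percentage points higher from compound 3 to compound 4 (within the scatter) is therefore expected to remain within the scatter. Compound 4 is expected to reach 64%, with a range from 52% to 76%.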

Compound 4, largest response reached (reported as efficacy), in percent of the reference or control that the assay uses: 60.4%
Compound 4: the middle estimate sits 3.6 percentage points above what was measured; low and high end bracket the measured number.
By their numbers in this assay, from the lowest: compounds 4, 3, 2 and 1 (each within the scatter of the next, the first and the last beyond it).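

On the saturated chain carbon bound to an amide-type nitrogen, the exchange of 2-hydroxy-2-methylpropyl for 3-methyloxetan-3-yl removes the hydrogen-bond donor and brings in a four-membered ring, and in this assay this gives a number 1.5 percentage points lower from compound 3 to compound 4 (within the scatter), so this double change to the group leaves the maximal response inside the usual spread. Against 1,2-dimethylpropyl on the amide-type nitrogen, the (3-methyloxetan-3-yl)methyl group also stays inside that spread, with a number 8.9 percentage points lower from compound 2 to compound 4 (within the scatter), but against 1,2,2-trimethylpropyl it gives a number 10.4 percentage points lower from compound 1 to compound 4 (beyond the scatter), the first step in this set to pass the scatter, and only by a modest margin. No measurement offered here explains the size of any of these steps.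

Because the donor leaves and the ring enters in a single exchange, the compounds shown cannot separate the two changes; an open-chain ether such as 2-methoxy-2-methylpropyl would lose the donor without adding a ring. Also open, going by these compounds, is how the maximal response would respond to an amine, a carboxylic acid or a longer chain at this same place on the amide-type nitrogen.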